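The source may report more compounds than this note shows. Statements on the series, on what has been measured and on what is new or still open speak of the compounds shown alone.

Among the compounds with values here, compound 2 `Cc1cc(S(=O)(=O)/N=C(\N)n2nccc2-c2ccccc2)c(SCc2cccc(Cl)c2)cc1Cl` sits second highest of the three numbers measured so far: in a functional assay on MCF7 cells (Homo sapiens) for cytotoxicity, read by MTT assay, with a stated time of 72 h (on this read-out lower numbers stand for stronger inhibition and higher numbers for weaker inhibition), compound 2 gives 88000 nM. Compound 1 `Cc1ccc(CSc2cc(Cl)c(C)cc2S(=O)(=O)/N=C(\N)n2nc(C)cc2-c2ccccc2)cc1` gives 89000 nM in this assay, a number that lies within the scatter of compound 2. Compound 3 `Cc1cc(-c2ccccc2)n(/C(N)=N/S(=O)(=O)c2cc(C)c(Cl)cc2SCc2cccc(Cl)c2)n1` gives 25000 nM; the step of a 3.5-fold lower number from compound 2 to compound 3 (0.55 log units; beyond the scatter) and the step of a 3.6-fold lower number from compound 1 to compound 3 (0.55 log units; beyond the scatter) both run beyond the scatter but stay modest. Compound 4 `Cc1cc(S(=O)(=O)/N=C(\N)n2nccc2-c2ccccc2)c(SCc2ccccc2Cl)cc1Cl` differs from compound 2 only in the benzyl group: 2-chlorophenyl in place of 3-chlorophenyl on a saturated chain carbon bound to a sulfur. Within the data shown here, of the measured steps, only the one from compound 1 to compound 3 touches the same place, and it swaps a different substituent, so its modest size gives at best a loose guide; the step from compound 2 to compound 3 concerns another part of the molecule. Among the measured compounds shown here, with no direct precedent for moving the chlorine within the ring, the expected step of a 1.4-fold lower number from compound 2 to compound 4 (0.13 log units; within the scatter) is small, most likely within the scatter, with a slight lean toward a lower number. Compound 4 is therefore estimated at 65000 nM in this assay, with a range from 20000 nM to 200000 nM.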

Compound 4, half-maximal inhibitory concentration: 24000 nM
The estimate for compound 4 lay 2.7-fold (0.43 log units) above the measured number; the range from low to high includes it.
By their numbers in this assay, from the lowest: compounds 4 and 3 (each within the scatter of the next); then compounds 2 and 1 (each within the scatter of the next).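

In this assay the step of a 3.7-fold lower number from compound 2 to compound 4 (0.56 log units; beyond the scatter) shows that the place of the chlorine on the benzyl ring matters, even though the two compounds have the same atoms. The earlier step at this position, a 3.6-fold lower number from compound 1 to compound 3 (0.55 log units; beyond the scatter), exchanged 4-methylphenyl for 3-chlorophenyl and so changed the substituent itself, whereas this one moves only the chlorine, and the change still lies beyond the scatter. Nothing available explains why the 2-chlorophenyl group gives the lower number.

From the compounds shown here alone, it remains open whether a 4-chlorophenyl group would continue this trend, or whether a 2-fluorophenyl or 2-methoxyphenyl group would match the 2-chlorophenyl result. Also unresolved is whether the 2-chlorophenyl change would combine with the methyl on the aromatic carbon seen in the step of a 3.5-fold lower number from compound 2 to compound 3 (0.55 log units; beyond the scatter).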